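Swapping Propyl for Trifluoromethyl on the Shared Core

A few compounds are considered here, and "the series" means these few. Any claim that something is new, unique, unknown or untested is made for them only; others in the source may bear on it.

Measured so far in an assay on Jurkat cells for activation of nuclear factor NF-kappa-B complex (Homo sapiens); on this read-out lower numbers stand for stronger inhibition and higher numbers for weaker inhibition:
compound 1, `O=C(Nc1cc(C(F)(F)F)cc(C(F)(F)F)c1)c1cnc(Cl)nc1-c1cccs1`, gives 9800 nM.
compound 2, `O=C(Nc1cc(C(F)(F)F)cc(C(F)(F)F)c1)c1cnc(C(F)(F)F)nc1C(F)(F)F`, gives only a limit, > 10000 nM.
compound 3, `CCCc1nc(Cl)ncc1C(=O)Nc1cc(C(F)(F)F)cc(C(F)(F)F)c1`, gives 500 nM.

Compound 3 holds the lowest number among the two full values; compound 1 sits well above it, with a 20-fold lower number from compound 1 to compound 3 (1.29 log units; beyond the scatter). Compound 4, `O=C(Nc1cc(C(F)(F)F)cc(C(F)(F)F)c1)c1cnc(Cl)nc1C(F)(F)F`, takes the next step: trifluoromethyl in place of propyl on an aromatic carbon. Within the data shown here, no measured step matches this change directly. Among the measured compounds shown here, the only measured step at this position, from compound 1 to compound 3, shows that the group here moves this assay strongly, and compound 2, carrying trifluoromethyl at this same place, reached only the limit (the limit of > 10000 nM in this assay, at which 1 of the 3 values shown sits). A weaker result than compound 3 is therefore expected for compound 4, as an 8.0-fold higher number from compound 3 to compound 4 (0.90 log units; beyond the scatter). Compound 4 is estimated at 4000 nM, between 700 nM and 20000 nM.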

Compound 4, half-maximal inhibitory concentration: 50 nM
Estimate against measurement, compound 4: 80-fold (1.90 log units) above, outside the stated range (below it).
By their numbers in this assay, from the lowest: compound 4; then compound 3; then compound 1. At a limit, above all of these: compound 2.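

Trifluoromethyl turns out to suit this position better than either earlier group, with a 10-fold lower number from compound 3 to compound 4 (1.00 log units; beyond the scatter) against propyl and a 200-fold lower number from compound 1 to compound 4 (2.29 log units; beyond the scatter) against thiophen-2-yl. Chloro in place of trifluoromethyl on the other substituted ring carbon gives an at least 200-fold lower number from compound 2 to compound 4 (2.30 log units; beyond the scatter), so trifluoromethyl at this position does not by itself bring a weak result. The value of compound 2 is only a limit: the limit of > 10000 nM in this assay, at which 1 of the 4 values shown sits.

Still open, going by these compounds, is how a methyl or ethyl group would compare at this position. On these data alone, it is also open whether an amine could replace the chloro group.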